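Swapping Isopropyl for Sulfamoyl on a Weak Kinase-Type Scaffold

The compounds below may be only part of what the source reports. "The series", "measured", "known", "first", "only" and "open" are said of these compounds alone.

Compound 1 `Cc1cnc(Nc2ccc(C(C)C)cc2)nc1Nc1nc2ccccc2s1` was tested in a functional assay on MDA-MB-231 cells (Homo sapiens) for antiproliferative activity, read by MTT assay, with a stated time of 48 h; on this read-out lower numbers stand for stronger inhibition and higher numbers for weaker inhibition. In this assay compound 1 gives > 50000 nM, which is a limit of the assay rather than a measured number (the limit of > 50000 nM in this assay, at which 1 of the 3 values shown sits). Two related compounds with a polar sulfur-containing group on the aniline ring were also measured: compound 2 `Cc1ccc2nc(Nc3nc(Nc4ccc(S(C)(=O)=O)cc4)ncc3F)sc2c1` gives 14300 nM, and compound 3 `NS(=O)(=O)c1ccc(Nc2ncc(F)c(Nc3nc4ccc(Cl)cc4s3)n2)cc1` gives 2790 nM. These two share neither the methyl on the shared core nor the unsubstituted benzothiazole of compound 1, so their values show only what such polar groups can reach, not a step from compound 1.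

Compound 4 `Cc1cnc(Nc2ccc(S(N)(=O)=O)cc2)nc1Nc1nc2ccccc2s1` differs from compound 1 in one place: sulfamoyl in place of isopropyl on an aromatic carbon. For the measured compounds named here, no measured pair covers this exact change. Since compound 3 carries the same sulfamoyl group and gives 2790 nM, the change is expected to strengthen inhibition by a step well beyond the usual scatter. Compound 4 is therefore expected to reach about 6000 nM, within a range of 1500 nM to 25000 nM, an expected step of an at least 8.3-fold lower number from compound 1 to compound 4 (0.92 log units; beyond the scatter).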

Compound 4, half-maximal inhibitory concentration: 16800 nM
Compound 4: the middle estimate sits 2.8-fold (0.45 log units) below what was measured, within the range that was stated.
By their numbers in this assay, from the lowest: compound 3; then compounds 2 and 4 (each within the scatter of the next). At a limit, above all of these: compound 1.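

Putting sulfamoyl in place of isopropyl on this aromatic carbon gives an at least 2.9-fold lower number from compound 1 to compound 4 (0.47 log units; beyond the scatter); compounds 2 and 3 differ from compound 1 in more than one place, so they could not show this single change. In this assay compound 1 gives > 50000 nM, which is a limit and not a number. The step is therefore only a lower bound on the true change, because compound 1 has no exact value to start from: the limit of > 50000 nM in this assay, at which 1 of the 4 values shown sits.

Still open, on these data alone, is whether this gain belongs to sulfamoyl in particular, or whether another group on the same aromatic carbon, such as an amine or a carboxylic acid, would give a similar step. Equally open, as far as these compounds go, is whether the same swap would have a similar effect on a core other than that of compound 1.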